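Series notes: thioamide side chain on the pyridazinone core

The source may report more compounds than this note shows. Statements on the series, on what has been measured and on what is new or still open speak of the compounds shown alone.

In a functional assay on the whole organism (stomach) for inhibition, with Rattus norvegicus as the target (on this read-out higher numbers stand for an effect only at larger amounts of compound and lower numbers for an effect already at smaller amounts), compound 2 `N=C(S)CCCn1nc(-c2ccccc2)ccc1=O` gives 10.5 mg/kg, the lowest of the two numbers in hand. Compound 1 `N=C(S)CCCCCCN1N=C(c2ccccc2)CCC1=O` gives 23 mg/kg in this assay, a higher number by a gap that is beyond the usual scatter. Compound 3 `Cc1ccc(=O)n(CCC(=N)S)n1` reaches only the limit of > 50 mg/kg in this assay, which is a limit and not a number; this is the case described by the limit of > 50 mg/kg in this assay, at which 1 of the 3 values shown sits.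

Among the compounds with values here, no step between measured compounds is given, so nothing in hand measures the effect of shortening the chain as such. Compound 4 `N=C(S)CCn1nc(-c2ccccc2)ccc1=O` differs from compound 2 by a group of 3 heavy atoms (1 carbon, 1 nitrogen, 1 sulfur; no ring) in place of a group of 4 heavy atoms (2 carbon, 1 nitrogen, 1 sulfur; no ring), on a saturated chain carbon, two bonds along the chain from an aromatic nitrogen. Within the data shown here, the change is small and of a kind for which no measured step exists; a modest shift toward higher numbers in this assay is expected, near the edge of the scatter, with a fair chance that only a limit is returned. The step from compound 2 to compound 4 is estimated as a 1.7-fold higher number from compound 2 to compound 4 (0.23 log units; within the scatter). For compound 4 the expected value in this assay is 18 mg/kg, with a likely range from 8 mg/kg to 45 mg/kg.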

Compound 4, dose for half-maximal effect: 34.5 mg/kg
The estimate for compound 4 lay 1.9-fold (0.28 log units) below the measured number; the measured number falls inside the stated range.
By their numbers in this assay, from the lowest: compound 2; then compounds 1 and 4 (each within the scatter of the next). At a limit, above all of these: compound 3.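

In this assay, within the data shown here, the saturated chain carbon two bonds along the chain from an aromatic nitrogen proves sensitive to a small change: the group of 3 heavy atoms in place of the group of 4 heavy atoms gives a 3.3-fold higher number from compound 2 to compound 4 (0.52 log units; beyond the scatter), the first measured step at this position. Phenyl in place of methyl on an aromatic carbon gives an at least 1.4-fold lower number from compound 3 to compound 4 (0.16 log units; that floor lies within the scatter), so the size of that change remains only a floor and cannot be separated from the scatter. Compound 3 gives a limit and not a number: the limit of > 50 mg/kg in this assay, at which 1 of the 4 values shown sits.

The compounds shown do not tell whether a longer chain on the core of compound 2 would extend this trend or reverse it. They also leave open whether an amine or a carboxylic acid at the chain end could take the place of the end group shared by all four compounds.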